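Replacing a pyrazole with a substituted pyridine on the shared core

A few compounds are considered here, and "the series" means these few. Any claim that something is new, unique, unknown or untested is made for them only; others in the source may bear on it.

Measured compounds in an assay on T-REx-293 cells for inhibition of potassium channel subfamily T member 1 (Homo sapiens), read by patch clamp; a higher number here means a weaker inhibitor, a lower number a stronger inhibitor:
compound 1 `Cc1cccc(-c2noc(C(C)NC(=O)c3cc(C4CC4)nn3C)n2)c1` gives 1880 nM
compound 2 `C[C@@H](c1nc(-c2cccc(F)c2)no1)N(C)C(=O)c1cc(C(F)(F)F)nn1C` gives 6490 nM
compound 3 `C[C@H](NC(=O)c1cc(C(F)(F)F)nn1C)c1nc(-c2cnn(C)c2)no1` gives 2640 nM

Among these three numbers compound 3 holds the second highest. Its nearest neighbour is compound 1, whose number is lower but lies within the usual scatter of repeated measurements, so no order can be read between the two. Compound 2, the furthest, gives a higher number that lies beyond the scatter.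

Compound 4 `CO[C@H](C)c1cc(-c2noc([C@H](C)NC(=O)c3cc(C(F)(F)F)nn3C)n2)ccn1` differs from compound 3 in one place: a group of 10 heavy atoms (8 carbon, 1 nitrogen, 1 oxygen; one six-membered aromatic ring with 1 hetero atom) in place of a group of 6 heavy atoms (4 carbon, 2 nitrogen; one five-membered aromatic ring with 2 hetero atoms), on an aromatic carbon

Among the compounds with values here, no measured pair here isolates this kind of change, and the two six-membered aryl groups in compound 1 and compound 2 sit on either side of compound 3 in this assay, so no direction can be inferred. The step of a 1.3-fold lower number from compound 3 to compound 4 (0.12 log units; within the scatter) is therefore expected to stay within the scatter. Compound 4 is estimated at 2000 nM, with a range from 500 nM to 8000 nM.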

Compound 4, half-maximal inhibitory concentration: 778 nM
For compound 4 the middle estimate is 2.6-fold (0.41 log units) above the measured one; the measured number falls inside the stated range.
By their numbers in this assay, from the lowest: compound 4; then compounds 1 and 3 (each within the scatter of the next); then compound 2.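

In this assay, putting the larger six-membered aromatic ring in place of the 1-methyl-1H-pyrazol-4-yl group gives a 3.4-fold lower number from compound 3 to compound 4 (0.53 log units; beyond the scatter), the only step shown at this place on the shared core. This place therefore accepts the larger group with its defined stereocentre, and inhibition gets stronger while the counts of hydrogen-bond donors and acceptors and the net charge stay the same. No measurement available here accounts for the gain.

The compounds shown do not separate the effect of the six-membered ring from that of the chain it carries, or show the other form of its stereocentre. On these data alone, whether an amine or a carboxylic acid on that ring would keep this level of inhibition also stays open.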